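The compounds below may be only part of what the source reports. "The series", "measured", "known", "first", "only" and "open" are said of these compounds alone.

Measured compounds:
Compound 1 `COc1cc(/C=C/c2nc(NC3CC3)c3sccc3n2)cc(OC)c1OC` gives 6030 nM in a functional assay on RAW264.7 cells (Mus musculus) for inhibition, read by Griess assay, with stated times of 1 h and 24 h; a lower number here means a stronger inhibitor, a higher number a weaker inhibitor.
Compound 2 `COc1cc(/C=C/c2nc(Nc3ccc(O)cc3)c3sccc3n2)cc(OC)c1OC` gives 4070 nM in this assay.

Among the compounds with values here, compound 2 stands as the lowest of the two numbers, but the only step to it, a 1.5-fold lower number from compound 1 to compound 2 (0.17 log units; within the scatter), lies within the usual scatter, so the two values cannot be told apart. Compound 3 `COc1cc(/C=C/c2nc(NCc3ccc(C)cc3)c3sccc3n2)cc(OC)c1OC` is not yet measured. It differs from compound 2 in one place: 4-methylbenzyl in place of 4-hydroxyphenyl on a nitrogen on an aromatic ring. Within the data shown here, the one measured step that bears on this position is the exchange of the group on the same nitrogen, a 1.5-fold lower number from compound 1 to compound 2 (0.17 log units; within the scatter), which was within the scatter. Among the measured compounds shown here, with only that step as a guide, the new group is expected to leave this assay about where compound 2 stands, with no step beyond the scatter in either direction, giving a 1.2-fold higher number from compound 2 to compound 3 (0.09 log units; within the scatter). Compound 3 is therefore estimated at 5000 nM, with a range from 2000 nM to 15000 nM.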

Compound 3, half-maximal inhibitory concentration: 1860 nM
Estimate against measurement, compound 3: 2.7-fold (0.43 log units) above; the measured number lies below the stated range.
By their numbers in this assay, from the lowest: compound 3; then compounds 2 and 1 (each within the scatter of the next).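

At this position the group on the nitrogen can shift the number in this assay beyond the scatter, which the first exchange did not show: 4-methylbenzyl in place of 4-hydroxyphenyl gives a 2.2-fold lower number from compound 2 to compound 3 (0.34 log units; beyond the scatter) and 4-methylbenzyl in place of cyclopropyl gives a 3.2-fold lower number from compound 1 to compound 3 (0.51 log units; beyond the scatter) in turn. Compound 3 therefore holds the lowest number of the three, although both steps are modest. The change also swaps a group with one hydrogen-bond donor and one acceptor for a group with neither, but no measurement shown here explains the lower number.

Compound 3 differs from compound 2 both in its methyl and in being a benzyl rather than a phenyl group, so the two changes cannot be separated. Plain benzyl and 4-hydroxybenzyl on the same nitrogen would pull them apart, and a longer chain ending in a phenyl ring would test how far the trend runs.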